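Methoxy for isobutylamino on a quinone-bearing terpenoid core

The compounds below may be only part of what the source reports. "The series", "measured", "known", "first", "only" and "open" are said of these compounds alone.

The series shares a core of the kind shown by compound 1 `C=C1CCC[C@H]2[C@](C)(CC3=C(O)C(=O)C=C(OC)C3=O)[C@@H](C)CC[C@@]12C`, which in a functional assay on PC-3 cells (Homo sapiens) for antiproliferative activity, read by MTT assay (on this read-out lower numbers stand for stronger inhibition and higher numbers for weaker inhibition), returns only a limit, > 10000 nM. Compound 2 `C=C1CCC[C@H]2[C@](C)(CC3=C(O)C(=O)C(CCCCC(C)=O)=C(OC)C3=O)[C@@H](C)CC[C@]12C` likewise gives only a limit in this assay, > 10000 nM. Compound 3 `C=C1CCC[C@H]2[C@](C)(CC3=C(O)C(=O)C=C(NCC(C)C)C3=O)[C@@H](C)CC[C@]12C` also reaches only the limit of this assay, > 10000 nM. Among the compounds with values here, compound 3 therefore stands nowhere on a numerical scale: all three measured values sit at the same limit, as the evidence states, (the limit of > 10000 nM in this assay, at which 3 of the 3 values shown sit), so no compound can be called stronger or weaker than another.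

Compound 4 `C=C1CCC[C@H]2[C@](C)(CC3=C(O)C(=O)C=C(OC)C3=O)[C@@H](C)CC[C@]12C` is the next compound to be tested. It differs from compound 3 by methoxy in place of isobutylamino on a double-bonded ring carbon. No measured step between two compounds is known here, so no expectation of size or direction can be drawn from measured pairs; the shared limit of the three measured compounds gives no reason to expect compound 4 to move beyond the scatter in either direction. Compound 4 is estimated at 15000 nM, with a range of 5000 nM to 50000 nM, which would mean an expected step that the limit leaves unreadable from compound 3 to compound 4.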

Compound 4, half-maximal inhibitory concentration: > 10000 nM
Compound 4: only a limit was reported (the forecaster's own chance of this, stated with the estimate: 85%); the middle value does not contradict the limit.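

Compound 4 also gives only a limit, > 10000 nM, in this assay. The steps from compound 1, compound 2 and compound 3 to compound 4 therefore cannot be read: the limit of > 10000 nM in this assay, at which 4 of the 4 values shown sit.

The compounds shown leave open whether any of these changes, including the drawn configuration, alters the antiproliferative activity at all.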